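The source may report more compounds than this note shows. Statements on the series, on what has been measured and on what is new or still open speak of the compounds shown alone.

Compound 1 `CCNC(=S)Nc1cccc(C(F)(F)F)c1`. In an ADME assay on Vero 76 cells (Chlorocebus sabaeus) for cytotoxicity, read by crystal violet staining, with a stated time of 96 h (a higher number here means that more compound is tolerated, a lower number that less compound is tolerated), compound 1 gives > 100000 nM, which is a limit of the assay and not a number.
Compound 2 `FC(F)(F)c1cccc(NC(=S)Nc2ccc(I)cc2)c1`; in this assay compound 2 gives 9500 nM.
Compound 3 `FC(F)(F)c1cccc(NC(=S)Nc2ccccc2Br)c1`; in this assay compound 3 gives 50000 nM.

Compound 3 holds the highest of the two numbers, the nearest being a 5.3-fold higher number from compound 2 to compound 3 (0.72 log units; beyond the scatter). Compound 4 `CC(=O)NC(=S)Nc1cccc(C(F)(F)F)c1` differs from compound 3 by acetyl in place of 2-bromophenyl on an amide-type nitrogen. Going by the values given here, the steps that bear on this are an at least 10-fold lower number from compound 1 to compound 2 (1.02 log units; beyond the scatter) and an at least 2.0-fold lower number from compound 1 to compound 3 (0.30 log units; that floor lies within the scatter), where an aryl group took the place of a small ethyl; removing the 2-bromophenyl in favour of a small acetyl runs the other way, so a rise in this assay toward the limit is expected. Compound 4 is therefore estimated at 90000 nM, within 30000 nM to 250000 nM, an expected step of a 1.8-fold higher number from compound 3 to compound 4 (0.26 log units; within the scatter).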

Compound 4, half-maximal cytotoxic concentration: > 100000 nM
Compound 4 was reported as a limit (the forecaster's own chance of this, stated with the estimate: 45%); at least 1.1-fold (0.04 log units) between middle value and limit.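

Compound 4 gives a limit and not a number in this assay: the limit of > 100000 nM in this assay, at which 2 of the 4 values shown sit.

On the amide-type nitrogen, acetyl in place of 4-iodophenyl gives an at least 10-fold higher number from compound 2 to compound 4 (1.02 log units; beyond the scatter), while acetyl in place of 2-bromophenyl gives an at least 2.0-fold higher number from compound 3 to compound 4 (0.30 log units; that floor lies within the scatter). So ethyl is not the only small group without a ring that reaches the limit, and the step between compound 1 and compound 4 cannot be read, since both are limits.

On these data alone, it remains open whether a longer chain or a chain carrying an amine on this nitrogen would also stay at the limit. As far as these compounds go, how compound 1 and compound 4 truly compare also stays unknown.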